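Swapping the anilino group: from methoxy to a carboxylic acid

The source may report more compounds than this note shows. Statements on the series, on what has been measured and on what is new or still open speak of the compounds shown alone.

Measured so far in a functional assay on MCF7 cells (Homo sapiens) for cytotoxicity, read by sulforhodamine B assay; a lower number here means a stronger inhibitor, a higher number a weaker inhibitor:
- Compound 1 `C=C1[C@@H](OC(C)=O)C[C@@H]2[C@](C)(CO[Si](C)(C)C(C)(C)C)[C@H](OC(C)=O)CC[C@@]2(C)[C@@H]1C[C@@H](Nc1ccc(OC)cc1)C1=CCOC1=O` gives 4280 nM.
- Compound 3 `C=C1[C@@H](OC(C)=O)C[C@@H]2[C@](C)(COC=O)[C@H](OC(C)=O)CC[C@@]2(C)[C@@H]1C[C@@H](Nc1ccc(OC)cc1)C1=CCOC1=O` gives 24200 nM.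
- Compound 2 `C=C1[C@@H](OC(C)=O)C[C@@H]2[C@](C)(COC=O)[C@H](OC(C)=O)CC[C@@]2(C)[C@@H]1C[C@@H](Nc1ccc(OC)c(OC)c1)C1=CCOC1=O` gives only a limit of the assay, > 50000 nM.

Among the two numbers shown, compound 1 has the lowest, so it is the strongest inhibitor of the measured set; its nearest neighbour is compound 3, and the change is a 5.7-fold higher number from compound 1 to compound 3 (0.75 log units; beyond the scatter). The step from compound 2 to compound 3, an at least 2.0-fold lower number from compound 2 to compound 3 (0.31 log units; beyond the scatter), shows that a change on the aromatic ring attached to the amine nitrogen can move the number beyond the scatter.

Compound 4 `C=C1[C@@H](OC(C)=O)C[C@@H]2[C@](C)(CO[Si](C)(C)C(C)(C)C)[C@H](OC(C)=O)CC[C@@]2(C)[C@@H]1C[C@@H](Nc1ccccc1C(=O)O)C1=CCOC1=O` keeps the silicon-containing group of compound 1 and changes only the aromatic ring on the amine: 2-carboxyphenyl in place of 4-methoxyphenyl on an amine nitrogen. Within the data shown here, no measured step covers this exact exchange. Among the measured compounds shown here, the only evidence on that ring is the step from compound 2 to compound 3, in which a methoxy on an aromatic carbon weakened the compound beyond the scatter. A carboxyphenyl group is a larger departure, so the step is expected to be a weakening, estimated as a 2.8-fold higher number from compound 1 to compound 4 (0.45 log units; beyond the scatter). For compound 4 the expected value in this assay is therefore 12000 nM, with a range from 2500 nM to 50000 nM.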

Compound 4, half-maximal inhibitory concentration: 4460 nM
For compound 4 the middle estimate is 2.7-fold (0.43 log units) above the measured one; the range from low to high includes it.
By their numbers in this assay, from the lowest: compounds 1 and 4 (each within the scatter of the next); then compound 3. At a limit, above all of these: compound 2.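

In this assay, placing 2-carboxyphenyl on the amine nitrogen in place of 4-methoxyphenyl gives a 1.0-fold higher number from compound 1 to compound 4 (0.02 log units; within the scatter) and so leaves the number where it was. The step between compound 2 and compound 3 had shown that a change on this ring can move the number, whereas this exchange shows that even replacing the whole aromatic group need not, although the entering group brings a hydrogen-bond donor that the leaving group lacks. The values shown do not explain why the number holds across this exchange.

From the compounds shown here alone, whether the carboxylic acid itself matters stays open, since a methyl ester, a primary amide or a plain phenyl ring at this position would test that. Also open, going by these compounds, is whether the same exchange would leave the number unchanged with the group of compound 3 in place of the silicon-containing group.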